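Fluoro in Place of Methyl on a Shared Core

The compounds below may be only part of what the source reports. "The series", "measured", "known", "first", "only" and "open" are said of these compounds alone.

This account concerns a small set of analogues built on one core and tested in an ADME assay on NIH3T3 cells (Mus musculus) for cytotoxicity, read by MTT assay, with a stated time of 24 h; a higher number here means a weaker inhibitor, a lower number a stronger inhibitor. Compound 1, with the structure `Cc1ccc(-c2cs/c(=N/NC(=O)CSc3nnnn3-c3ccccc3)n2-c2ccccc2)cc1`, is the reference point. In this assay compound 1 gives only > 500 ug/mL, which is a limit of the assay rather than a measured number. Among the three values shown, compound 1 therefore sits at the limit of > 500 ug/mL in this assay, at which 1 of the 3 values shown sits. Two further analogues carry numbers rather than limits. Compound 2, with the structure `Cn1cnnc1SCC(=O)N/N=c1/scc(-c2ccc(C#N)cc2)n1-c1ccccc1`, gives 153 ug/mL in this assay. Compound 3, with the structure `COc1ccc(-c2cs/c(=N/NC(=O)CSc3nnc(C)s3)n2-c2ccccc2)cc1`, gives 300 ug/mL in this assay. For the measured compounds named here, no step between any two of these measured compounds is given, so of each pair only the two values themselves can be read.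

The compound still to be measured is compound 4, with the structure `O=C(CSc1nnnn1-c1ccccc1)N/N=c1/scc(-c2ccc(F)cc2)n1-c1ccccc1`. It differs from compound 1 in one place: fluoro in place of methyl on an aromatic carbon. Both compounds keep the same core and the same remaining substituents. Since compound 1 is known only as a limit, the step of an at least 1.2-fold lower number from compound 1 to compound 4 (0.09 log units; that floor lies within the scatter) is expected to be small, with no change beyond the usual scatter. Compound 4 is expected to give about 400 ug/mL in this assay, within a range from 150 ug/mL to 600 ug/mL.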

Compound 4, half-maximal inhibitory concentration: 207 ug/mL
Compound 4: the middle estimate sits 1.9-fold (0.29 log units) above what was measured, and the stated range covers the measured number.
By their numbers in this assay, from the lowest: compounds 2, 4 and 3 (each within the scatter of the next). At a limit, above all of these: compound 1.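

In this assay, the change from 4-methylphenyl to 4-fluorophenyl, on an aromatic carbon para to a large group, gives an at least 2.4-fold lower number from compound 1 to compound 4 (0.38 log units; beyond the scatter). For the compounds shown here, this is the first single-place comparison in the set, and it shows that this position on the shared core is not silent: exchanging one heavy atom here takes the read-out from an assay limit to a measured number, by a margin beyond the usual scatter. From the compounds shown here alone, the step can be given only as a floor, and its true size stays unknown, because compound 1 is held at a limit of the assay rather than at a number: the limit of > 500 ug/mL in this assay, at which 1 of the 4 values shown sits.

What the compounds shown leave open is how far this position tolerates other groups, since a plain hydrogen, a chloro group or an amine at the same place on the core of compound 1 would be needed to tell whether the step follows the loss of methyl or the arrival of fluoro. Going by these compounds, it also remains open whether the same exchange of methyl for fluoro gives a step of similar size when the remaining substituents of the core are changed.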